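Trading a bicyclic amine for a pyrrolidine on the shared core

A few compounds are considered here, and "the series" means these few. Any claim that something is new, unique, unknown or untested is made for them only; others in the source may bear on it.

Of the compounds shown here, three with a shared core have been tested in an assay on isolated protein for agonist activity at Gonadotropin-releasing hormone receptor (Homo sapiens); on this read-out lower numbers stand for stronger inhibition and higher numbers for weaker inhibition. Compound 1 `CCCC(=O)Nc1ccc(-c2nc3n(Cc4ccccc4F)cc(C(=O)OC(CC)CC)c(=O)n3c2CN(C)Cc2ccco2)cc1` gives 29 nM, compound 2 `CCCC(=O)Nc1ccc(-c2nc3n(Cc4ccccc4F)cc(C(=O)OC(CC)CC)c(=O)n3c2CN(C)CC#N)cc1` gives 300 nM, and compound 3 `CCCC(=O)Nc1ccc(-c2nc3n(Cc4ccccc4F)cc(C(=O)OC(CC)CC)c(=O)n3c2N2CCC3C=CC=CC3C2)cc1` gives 290 nM, placing compound 3 second highest of the three, with compound 2 within the scatter of it. Compound 4 `CCCC(=O)Nc1ccc(-c2nc3n(Cc4ccccc4F)cc(C(=O)OC(CC)CC)c(=O)n3c2CN2CCCC2)cc1` carries a group of 6 heavy atoms (5 carbon, 1 nitrogen; one five-membered non-aromatic ring with 1 hetero atom) in place of a group of 10 heavy atoms (9 carbon, 1 nitrogen; one six-membered non-aromatic ring of carbon only, one six-membered non-aromatic ring with 1 hetero atom), on an aromatic carbon. Within the data shown here, two measured steps bear on this position: a 10-fold higher number from compound 1 to compound 3 (1.00 log units; beyond the scatter) and a 1.0-fold lower number from compound 2 to compound 3 (0.01 log units; within the scatter). The pyrrolidinylmethyl group of compound 4 resembles the small amine-bearing chain of compound 2 more than the furan-bearing chain of compound 1, so little change beyond the scatter is expected, giving a 1.6-fold lower number from compound 3 to compound 4 (0.21 log units; within the scatter). Compound 4 is therefore estimated at 180 nM, within a range of 45 nM to 700 nM.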

Compound 4, inhibition constant: 2200 nM
Estimate against measurement, compound 4: 12-fold (1.09 log units) below; measured number outside the range, above it.
By their numbers in this assay, from the lowest: compound 1; then compounds 3 and 2 (each within the scatter of the next); then compound 4.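

Compound 4 gives the weakest inhibition of the four, with a 76-fold higher number from compound 1 to compound 4 (1.88 log units; beyond the scatter) and a 7.3-fold higher number from compound 2 to compound 4 (0.87 log units; beyond the scatter) against the open-chain amines, and a 7.6-fold higher number from compound 3 to compound 4 (0.88 log units; beyond the scatter) for the change at this position. A small amine on this saturated chain carbon therefore does not guarantee the level of compound 2: what the nitrogen carries, or how it is tied into a ring, matters here. Nothing shown gives a reason for this loss. Going by these compounds, whether a (piperidin-1-yl)methyl or a (dimethylamino)methyl group would stay close to compound 4 or come nearer to compound 2 remains open.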